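A few compounds are considered here, and "the series" means these few. Any claim that something is new, unique, unknown or untested is made for them only; others in the source may bear on it.

The compounds share the core of compound 1 `CC1CCCc2c1[nH]c(=O)c(C#N)c2-c1cccn1C`. In a functional assay on CCRF-CEM cells (Homo sapiens) for inhibition, read by sulforhodamine B assay, with a stated time of 48 h (a lower number here means a stronger inhibitor of growth, a higher number a weaker inhibitor of growth), compound 1 gives only a limit, > 100000 nM. Compound 2 `Cn1cccc1-c1cc(-c2cccs2)[nH]c(=O)c1C#N` carries a thiophen-2-yl group. In this assay compound 2 likewise stops at a limit, > 100000 nM. Both measured values rest at the limit of > 100000 nM in this assay, at which 2 of the 2 values shown sit, so compound 2 stands nowhere else than at that ceiling. Compound 3 `Cn1cccc1-c1cc(-c2ccccc2)[nH]c(=O)c1C#N` arises through the change (phenyl in place of thiophen-2-yl on an aromatic carbon). Within the data shown here, no measured step exists to show a direction, so compound 3 is expected to stay near that ceiling, with an expected step that the limit leaves unreadable from compound 2 to compound 3. For compound 3 the growth inhibition concentration is estimated at 150000 nM, ranging from 30000 nM to 500000 nM.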

Compound 3, concentration for 50% growth inhibition: > 100000 nM
Compound 3 gave a limit, no number; the forecaster's own chance of this, stated with the estimate: 80%; the middle value lies beyond the limit too.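

In this assay, among these compounds, compound 3, like compound 2, gives only a limit, so no step between compound 2 and compound 3 can be read. The compounds shown leave open whether phenyl in place of thiophen-2-yl alters growth inhibition at all.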